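The source may report more compounds than this note shows. Statements on the series, on what has been measured and on what is new or still open speak of the compounds shown alone.

Working notes on the series.

Of the compounds shown here, two have been measured in an ADME assay on the whole organism for inhibition, with Echinochloa crus-galli var. formosensis as the target, with a stated time of 4 days; on this read-out lower numbers stand for stronger inhibition and higher numbers for weaker inhibition. Compound 1, `CNc1nc(Cl)nc(N[C@@H](C)c2ccccc2)n1`, gives 26900 nM in this assay. Compound 2, `CCN(c1nc(Cl)nc(N[C@H](C)c2ccccc2)n1)C(C)C`, gives 52500 nM in this assay. The two values lie within the usual scatter of each other, so the data so far describe a single level of inhibition rather than any ordering among the measured compounds; compound 2 simply stands at this shared level.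

The next compound, compound 3, `CCCN(C)c1nc(Cl)nc(N[C@H](C)c2ccccc2)n1`, differs from compound 2 at one place: methyl(propyl)amino in place of ethyl(isopropyl)amino on an aromatic carbon. Both groups carry no ring, no hydrogen-bond donor and one hydrogen-bond acceptor, and the counted size drops by one heavy atom. Among the measured compounds shown here, no step between measured compounds in this assay is available to read from, and the change between the two measured compounds is of a different kind, so nothing in the data points either way.

The expectation for compound 3 is therefore that it stays at the level of compound 2, with an estimated step from compound 2 to compound 3 of a 1.2-fold lower number from compound 2 to compound 3 (0.07 log units; within the scatter), which is no step beyond the scatter. The estimate for compound 3 in this assay is 45000 nM, within a range from 15000 nM to 130000 nM.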

Compound 3, half-maximal inhibitory concentration: 9770 nM
Compound 3: the middle estimate sits 4.6-fold (0.66 log units) above what was measured; measured number outside the range, below it.
By their numbers in this assay, from the lowest: compound 3; then compounds 1 and 2 (each within the scatter of the next).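

The group on the aromatic carbon opposite the ring nitrogen, between two ring nitrogen atoms, does affect the read-out in this assay: methyl(propyl)amino in place of ethyl(isopropyl)amino gives a 5.4-fold lower number from compound 2 to compound 3 (0.73 log units; beyond the scatter) and so moves inhibition to a stronger level, a modest step beyond the scatter. Among the compounds shown here, this is the first readable step, and it shows that this position responds to a change of the amino substituents alone, even though the counts of rings, hydrogen-bond donors and hydrogen-bond acceptors stay the same and the chloro group and the rest of the core are untouched. No available evidence bears on the origin of this step.

Both chains on the amino nitrogen differ between compound 2 and compound 3, so the compounds shown cannot separate the contribution of ethyl giving way to methyl from that of isopropyl giving way to propyl. On these data alone, it also remains open how far the response at this position extends, for example to dimethylamino, to a longer chain such as butyl(methyl)amino, or to a cyclic amine such as piperidine.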